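This account rests on a few compounds, and the source may have more. Where it says the series, first, only, none or still open, it means among the compounds named here.

Compound 1 `COc1ccc(CCCCCCC(=O)c2ncc(-c3ccccn3)o2)cc1` gives 6.2 nM in an assay for inhibition of Fatty-acid amide hydrolase 1 (Rattus norvegicus); a lower number here means a stronger inhibitor, a higher number a weaker inhibitor; compound 2 `CC(C)(C)OC(=O)Nc1ccc(CCCCCCC(=O)c2ncc(-c3ccccn3)o2)cc1` gives 5.6 nM in this assay.

Compound 1 holds the higher of the two numbers, and its nearest neighbour is compound 2, the step from one to the other being a 1.1-fold lower number from compound 1 to compound 2 (0.04 log units; within the scatter). Compound 3 `CN(CCCCCC(=O)c1ncc(-c2ccccn2)o1)c1ccccc1` differs from compound 1 by methyl(phenyl)amino in place of 4-methoxybenzyl on a saturated chain carbon, five bonds along the chain from a carbonyl carbon. Among the compounds with values here, the only measured step, a 1.1-fold lower number from compound 1 to compound 2 (0.04 log units; within the scatter), touches a substituent on the aromatic ring and not the chain, so it does not bear on this change. With no measured guide, compound 3 is expected to be somewhat weaker, an estimated step of a 4.0-fold higher number from compound 1 to compound 3 (0.61 log units; beyond the scatter). Compound 3 is therefore estimated at 25 nM, within 5 nM to 120 nM.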

Compound 3, inhibition constant: 40 nM
Compound 3: middle estimate off by 1.6-fold (0.20 log units), on the low side, and the stated range covers the measured number.
By their numbers in this assay, from the lowest: compounds 2 and 1 (each within the scatter of the next); then compound 3.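

In this assay, the chain position responds where the earlier aromatic-ring change stayed within the scatter: methyl(phenyl)amino in place of 4-methoxybenzyl gives a 6.5-fold higher number from compound 1 to compound 3 (0.81 log units; beyond the scatter). The two groups count alike in hydrogen-bond donors and acceptors and each holds one six-membered aromatic ring of carbon only, so these counts do not separate them. Nothing available accounts for the step. The compounds shown leave open whether the ring nitrogen, its methyl or the missing methoxy drives this step, and how a phenoxy group or an unsubstituted benzyl group would fare at this position.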